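The source may report more compounds than this note shows. Statements on the series, on what has been measured and on what is new or still open speak of the compounds shown alone.

Three compounds have been measured in an assay on LM cells for displacement of a labelled ligand from Neuropeptide Y receptor type 5 (Homo sapiens); a lower number here means a stronger inhibitor, a higher number a weaker inhibitor:

Compound 1 `Fc1ccc(C2(c3ccc(F)cc3)CNC(c3cccc(Cl)c3)=N2)cc1`: 5.4 nM
Compound 2 `Fc1ccc(C2(c3ccc(F)cc3)CNC(c3cccc(Br)c3)=N2)cc1`: 4.8 nM
Compound 3 `Fc1ccc(C2(c3ccc(F)cc3)CNC(c3cccc(F)c3)=N2)cc1`: 10 nM

All three share the same core and differ only in the group on the single ring at one end. Compound 3 carries the fluoro group and has the highest number of the three. The step of a 1.9-fold higher number from compound 1 to compound 3 (0.27 log units; within the scatter) is within the scatter, while the step of a 2.1-fold higher number from compound 2 to compound 3 (0.32 log units; beyond the scatter) is modest and just beyond it. The step of a 1.1-fold lower number from compound 1 to compound 2 (0.05 log units; within the scatter) shows no real difference between chloro and bromo.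

Compound 4 `N#Cc1cccc(C2=NC(c3ccc(F)cc3)(c3ccc(F)cc3)CN2)c1` changes this same group: cyano in place of fluoro on an aromatic carbon. Among the measured compounds shown here, none of the measured steps involves a cyano group, so they do not speak to it directly; they show only that swapping the group at this position has moved the number by little, with the fluoro compound at the high end. A small step in either direction is therefore expected, the estimate being a 1.3-fold lower number from compound 3 to compound 4 (0.10 log units; within the scatter). Compound 4 is expected to give about 8 nM, between 2.5 nM and 30 nM.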

Compound 4, half-maximal inhibitory concentration: 2.7 nM
Compound 4: middle estimate off by 3.0-fold (0.47 log units), on the high side, and the stated range covers the measured number.
By their numbers in this assay, from the lowest: compounds 4, 2, 1 and 3 (each within the scatter of the next, the first and the last beyond it).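

In this assay, cyano at this position gives a larger step than any of the earlier swaps between halogens: a 3.7-fold lower number from compound 3 to compound 4 (0.57 log units; beyond the scatter). Set against the chloro and bromo compounds, the nitrile shows no real difference, with a 1.8-fold lower number from compound 2 to compound 4 (0.25 log units; within the scatter) and a 2.0-fold lower number from compound 1 to compound 4 (0.30 log units; within the scatter), so a halogen is not needed here to keep the number low, and only the fluoro compound stands apart from compound 4. No measurement here explains these differences.

The compounds shown leave open whether other groups at this position, such as an amine, a carboxylic acid or a methoxy group, would keep the number this low. They also leave open whether the change from 3-fluorophenyl to 3-cyanophenyl would give a similar step on a different core.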